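This account rests on a few compounds, and the source may have more. Where it says the series, first, only, none or still open, it means among the compounds named here.

Measured compounds:

Compound 1, `CC(=O)OC/C(=C\c1ccc(Cl)cc1Cl)C(=O)c1ccccc1`: in a functional assay on WiDr cells (Homo sapiens) for inhibition, read by sulforhodamine B assay, with a stated time of 48 h (on this read-out higher numbers stand for weaker inhibition of growth and lower numbers for stronger inhibition of growth), compound 1 gives 14000 nM.
Compound 2, `CC(=O)OC/C(=C\C1CCCCC1)C(=O)c1ccc(Cl)cc1`: compound 2 gives 21000 nM.
Compound 3, `CC(=O)OC/C(=C\c1ccc(Cl)cc1)C(=O)c1ccc(Cl)cc1`: compound 3 gives 18000 nM.

All three numbers sit close together, and every pair of them lies within the usual scatter of repeated measurements, so compound 3 cannot be set apart from compound 1 or from compound 2 on these figures. Among the compounds with values here, the only one-place step among the measured compounds is a 1.2-fold lower number from compound 2 to compound 3 (0.07 log units; within the scatter), which is also within the scatter.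

Compound 4, `CC(=O)OC/C(=C\c1ccc(Cl)cc1Cl)C(=O)c1ccc(Cl)cc1`, differs from compound 3 by chloro in place of hydrogen on an aromatic carbon. Within the data shown here, no measured pair shows this exact change on its own, so the expectation rests on a weaker hint. Compound 1 already carries the 2,4-dichlorophenyl group that compound 4 will carry, attached to a different ketone, and the values of compound 1 and compound 3 fall within the scatter of each other. Nothing in the data points to a change beyond the scatter in either direction, so the step from compound 3 to compound 4 is expected to be a 1.2-fold lower number from compound 3 to compound 4 (0.08 log units; within the scatter) in this assay. Compound 4 is therefore estimated at 15000 nM, with a range from 7000 nM to 35000 nM.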

Compound 4, concentration for 50% growth inhibition: 8100 nM
Compound 4: the middle estimate sits 1.9-fold (0.27 log units) above what was measured, within the range that was stated.
By their numbers in this assay, from the lowest: compounds 4, 1, 3 and 2 (each within the scatter of the next, the first and the last beyond it).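

In this assay, within the data shown here, changing 4-chlorophenyl to 2,4-dichlorophenyl gives the first single change to clear the usual scatter, though only modestly (a 2.2-fold lower number from compound 3 to compound 4 (0.35 log units; beyond the scatter)), with the new chloro ortho to a large group. Putting 2,4-dichlorophenyl in place of cyclohexyl also clears it, again modestly (a 2.6-fold lower number from compound 2 to compound 4 (0.41 log units; beyond the scatter)), whereas 4-chlorophenyl in place of cyclohexyl did not (a 1.2-fold lower number from compound 2 to compound 3 (0.07 log units; within the scatter)), so among these compounds only the group with the added chloro separates from cyclohexyl. The same kind of change made on the other aromatic ring, where phenyl on the carbonyl becomes 4-chlorophenyl, stays within the scatter (a 1.7-fold lower number from compound 1 to compound 4 (0.24 log units; within the scatter)), so that change cannot be read as having any effect here.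

No measurement shown explains why the added chloro goes with stronger inhibition of growth. Also open, on these data alone, is whether a methoxy group or an amine on that same aromatic carbon would move the number the same way, and whether the acetate ester could give way to a carboxylic acid or a longer chain with the growth inhibition kept.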